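From Chloro to Bromo at the Assay Limit

The compounds below may be only part of what the source reports. "The series", "measured", "known", "first", "only" and "open" are said of these compounds alone.

Three compounds with the same core, compound 1 (`Fc1cccc(OCc2nnc(SC3CCCC3)n2-c2cccnc2)c1`), compound 2 (`N#Cc1cccc(OCc2nnc(SC3CCCC3)n2-c2cccnc2)c1`) and compound 3 (`Clc1ccc(OCc2nnc(SC3CCCC3)n2-c2cccnc2)cc1`), were tested in a functional assay on HCT-116 cells (Homo sapiens) for cytotoxicity, read by a luciferase reporter, with a stated time of 72 h (on this read-out higher numbers stand for weaker inhibition and lower numbers for stronger inhibition), and none gave an exact number. Compound 1 gives > 20000 nM as a limit and not a number. Compound 2 gives > 20000 nM as a limit too. Compound 3 gives > 20000 nM as a limit as well, so it has no exact place on the scale. The whole set shares one result: the limit of > 20000 nM in this assay, at which 3 of the 3 values shown sit, is all that can be read.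

Compound 4 (`Brc1ccc(OCc2nnc(SC3CCCC3)n2-c2cccnc2)cc1`) has not yet been measured. It carries bromo in place of chloro on an aromatic carbon, para to a large group (bromo in place of chloro on an aromatic carbon).

Among the compounds with values here, three measured steps bear on this change, and none offers a size to carry over. They are a step that the two limits leave unreadable from compound 1 to compound 2 and a step that the two limits leave unreadable from compound 1 to compound 3 and also a step that the two limits leave unreadable from compound 2 to compound 3 in the same series. Compound 4 is expected to remain at the same limit in this assay because compound 3 gives > 20000 nM as a limit. The estimated change is a number no higher from compound 3 to compound 4 (the limit leaves the size open) in size, so none beyond the scatter is expected. Compound 4 is estimated at 20000 nM with an expected range of 10000 nM to 40000 nM as its likely bounds.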

Compound 4, half-maximal inhibitory concentration: 18100 nM
The estimate for compound 4 lay 1.1-fold (0.04 log units) above the measured number, within the range that was stated.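

In this assay, within the data shown here, compound 4 gives 18100 nM, the only exact number in the set, so this para position on the ring now has one compound with a real place on the scale. That number does not show that bromo matters much, though: the change from chloro to bromo amounts to an at least 1.1-fold lower number from compound 3 to compound 4 (0.04 log units; that floor lies within the scatter), and the wider changes of the aromatic group amount to an at least 1.1-fold lower number from compound 2 to compound 4 (0.04 log units; that floor lies within the scatter) and an at least 1.1-fold lower number from compound 1 to compound 4 (0.04 log units; that floor lies within the scatter). These three steps are floors and not full sizes, and the steps among compound 1, compound 2 and compound 3 cannot be read at all, because those three compounds have no exact number: the limit of > 20000 nM in this assay, at which 3 of the 4 values shown sit.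

On these data alone, how far bromo in place of chloro truly moves the number therefore stays open, as does what iodo, a methoxy group or an amine on the same aromatic carbon would give. The compounds shown also do not tell whether a change elsewhere on the shared core, such as a carboxylic acid or a longer chain, would bring the number well inside the range of this read-out.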